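This account rests on a few compounds, and the source may have more. Where it says the series, first, only, none or still open, it means among the compounds named here.

Measured in a functional assay on U-373MG ATCC cells for inhibition, with U373 MG (Homo sapiens) as the target, read by MTT assay, with a stated time of 72 h; a lower number here means a stronger inhibitor of growth, a higher number a weaker inhibitor of growth:
- Compound 1 `CC(C)=CC(=O)NC(=N)N`: > 100000 nM, a limit of the assay and not a number.
- Compound 2 `CC(C)=CC(=O)NC(=N)NC(=O)C=C(C)C`: 45600 nM.
- Compound 3 `CC(C)=CCC/C(C)=C/C(=O)NC(=N)NC(=O)/C=C(\C)CCC=C(C)C`: 38900 nM.

Compound 1 stands only at a limit: the limit of > 100000 nM in this assay, at which 1 of the 3 values shown sits. Compound 4 `CC(C)=CCC/C(C)=C/C(=O)NC(=N)N` is compound 1 with 3-methylbut-2-en-1-yl in place of hydrogen on a saturated chain carbon bound to a double-bonded chain carbon. Compound 2 at 45600 nM and compound 3 at 38900 nM lie within the usual scatter of each other, and neither shows strong growth inhibition in this assay. Only a modest gain is therefore expected. The estimated step of an at least 1.5-fold lower number from compound 1 to compound 4 (0.18 log units; that floor lies within the scatter) is small, towards stronger inhibition, and might not clear the limit. For compound 4 the expected value is 65000 nM, with an estimated range of 30000 nM to 100000 nM.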

Compound 4, concentration for 50% growth inhibition: 46000 nM
Estimate against measurement, compound 4: 1.4-fold (0.15 log units) above, and the stated range covers the measured number.
By their numbers in this assay, from the lowest: compounds 3, 2 and 4 (each within the scatter of the next). At a limit, above all of these: compound 1.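

With 3-methylbut-2-en-1-yl in place of hydrogen on a saturated chain carbon bound to a double-bonded chain carbon, this assay shows an at least 2.1-fold lower number from compound 1 to compound 4 (0.33 log units; beyond the scatter) and so gives a first readable gain at this position. Compound 1 stands at > 100000 nM as a limit of the assay and not a number. The full size of the step cannot be stated because of that limit: the limit of > 100000 nM in this assay, at which 1 of the 4 values shown sits.

The compounds shown leave open how a shorter or longer chain at this place would read. They also leave open what an amine or a carboxylic acid there would do.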